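A few compounds are considered here, and "the series" means these few. Any claim that something is new, unique, unknown or untested is made for them only; others in the source may bear on it.

Two compounds built on the same core were tested in a functional assay on SGC-7901 cells (Homo sapiens) for antiproliferative activity, read by MTT assay, with a stated time of 72 h; a lower number here means a stronger inhibitor, a higher number a weaker inhibitor. Compound 1, `COc1cc2c(Nc3ccc(F)c(Cl)c3F)ncnc2c(OC)c1OC`, gives only a limit in this assay, > 30000 nM. That reading is a limit of the measurement and not a number; compound 1 sits at the limit of > 30000 nM in this assay, at which 1 of the 2 values shown sits. For the measured compounds named here, compound 2, `COc1cc2c(Nc3cc(F)ccc3Br)ncnc2c(OC)c1OC`, gives 18400 nM in this assay, and it thus stands as the only plain number in this small set, a weak inhibitor by any reading.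

Compound 3, `COc1cc2c(Nc3ccc(Br)c(F)c3)ncnc2c(OC)c1OC`, is not yet measured. Compared with compound 2, the same atoms are joined differently: 4-bromo-3-fluorophenyl in place of 2-bromo-5-fluorophenyl on a nitrogen on an aromatic ring. Going by the values given here, no step between two measured compounds is available to show how much such a rearrangement on the ring attached to that nitrogen can move the result, so the expectation rests on the weakness of compound 2 alone.

The step from compound 2 to compound 3 is expected to be small, a 1.2-fold lower number from compound 2 to compound 3 (0.09 log units; within the scatter), not clearly beyond the usual scatter in either direction. Compound 3 is therefore estimated at 15000 nM in this assay, with a plausible range from 4000 nM to 30000 nM.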

Compound 3, half-maximal inhibitory concentration: > 30000 nM
Compound 3: only a limit was reported; the forecaster's own chance of this, stated with the estimate: 35%; middle value at least 2.0-fold (0.30 log units) away from the limit.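

For the compounds shown here, replacing 2-bromo-5-fluorophenyl with 4-bromo-3-fluorophenyl on the nitrogen gives the first step at this place that can be read in this assay, an at least 1.6-fold higher number from compound 2 to compound 3 (0.21 log units; that floor lies within the scatter), and that floor does not separate the two compounds beyond the usual scatter. From the compounds shown here alone, compound 3 gives > 30000 nM, which is a limit of the assay and not a number, so the full size of the step stays unknown. The rearrangement of the same atoms on this ring therefore brings no measurable gain, and the small set now rests mostly on limits: the limit of > 30000 nM in this assay, at which 2 of the 3 values shown sit.

Going by these compounds, how far the true value of compound 3 lies from its limit remains open, and so does whether the step is in fact larger than the scatter. Also open, on these data alone, is whether a different group, such as an amine or a carboxylic acid in place of the bromine on this ring, would give a number lower than that of compound 2, 18400 nM.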